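The compounds below may be only part of what the source reports. "The series", "measured", "known", "first", "only" and "open" are said of these compounds alone.

Measured in an assay on membranes from HeLa cells for displacement of a labelled ligand from adenosine receptor A3 (Homo sapiens), read by scintillation counting, with a stated time of 180 min, tested at 1 uM; on this read-out lower numbers stand for less inhibition and higher numbers for more inhibition at the one concentration tested (going by the name of the read-out):

compound 1, `CCCOC(=O)C1=C(C)NC(=O)NC1c1ccoc1`: 11%
compound 2, `CCCOC(=O)C1=C(C)NC(=O)NC1c1cccs1`: 32%
compound 3, `COC(=O)C1=C(C)N(C)C(=O)NC1c1ccoc1`: 7%

Within this set, the one single-point change that has been measured is thiophen-2-yl in place of furan-3-yl on a saturated ring carbon, which gave a number 21 percentage points higher from compound 1 to compound 2 (beyond the scatter). Compound 3 stands lowest of the three numbers in this assay; its value and that of compound 1 lie within the scatter of each other, while compound 2 lies beyond the scatter above it. The difference between the core of compound 1 and the core of compound 3 is not broken down here.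

Compound 4, `COC(=O)C1=C(C)N(C)C(=O)NC1c1cccs1`, is not yet measured. It is reached from compound 3 by thiophen-2-yl in place of furan-3-yl on a saturated ring carbon. Going by the values given here, this is the same kind of change as the one from compound 1 to compound 2, though the surroundings differ: in compound 4 the saturated ring carbon is next to the ring atom that bears a methoxycarbonyl group rather than a propoxycarbonyl group, and it also lies three ring bonds from the ring atom that bears a methyl group. Among the compounds with values here, for compound 4 in this assay a step of a number 18 percentage points higher from compound 3 to compound 4 (beyond the scatter) is expected, resting on the single measured precedent a number 21 percentage points higher from compound 1 to compound 2 (beyond the scatter), with some allowance for the different core. Compound 4 is therefore estimated at 25%, within a range of 10% to 42%.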

Compound 4, a percentage reported as inhibition, at one concentration (the size of the read-out at that concentration, not a potency): 15%
The estimate for compound 4 lay 10 percentage points above the measured number; the measured number falls inside the stated range.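

In this assay, thiophen-2-yl in place of furan-3-yl on a saturated ring carbon gave a number 8 percentage points higher from compound 3 to compound 4 (within the scatter), so on the core of compound 3 the change cannot be told from the usual spread of repeat measurements. Set beside the earlier step, the result gives no sign that the core alters the effect of this change: the same change on two cores in this assay, a number 21 percentage points higher (beyond the scatter) from compound 1 to compound 2 and a number 8 percentage points higher (within the scatter) from compound 3 to compound 4, 13 percentage points apart, within the scatter of two such steps. Going by these compounds alone, this fits a change that carries from one core to the other, but it does not establish transfer, since only two pairs are available and the step passes the scatter on the core of compound 1 alone.

The cores differ in both the ester and a further methyl group, and the compounds shown leave open which of these, if either, matters for the size of the step. Also open, on these data alone, is how the series responds when a group such as an amine or a carboxylic acid stands on the saturated ring carbon in place of the five-membered aromatic ring.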